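From Butyl to Ethoxycarbonyl: What Compound 4 Might Show

The source may report more compounds than this note shows. Statements on the series, on what has been measured and on what is new or still open speak of the compounds shown alone.

Three compounds have been measured in an ADME assay on HEK293 cells (Homo sapiens) for cytotoxicity, read by sulforhodamine B assay, with a stated time of 48 h, tested at 10 uM; on this read-out higher numbers stand for more inhibition at the one concentration tested (going by the name of the read-out) and lower numbers for less inhibition:
compound 1 `CCCCc1cn(C(c2ccccc2)c2cc3cc(Br)ccc3nc2OC)nn1`, -3.47%;
compound 2 `COc1nc2ccc(Br)cc2cc1C(c1ccccc1)n1cc(CCCCCO)nn1`, 7.96%;
compound 3 `CCCCCCCCc1cn(C(c2ccccc2)c2cc3cc(Br)ccc3nc2OC)nn1`, 14.6%.

Compound 1 stands lowest of the three. The step of a number 11.4 percentage points higher from compound 1 to compound 2 (beyond the scatter) brings hydroxymethyl in place of hydrogen on the chain, and the step of a number 18.1 percentage points higher from compound 1 to compound 3 (beyond the scatter) brings butyl in place of hydrogen at the same chain carbon; both lift the number modestly, beyond the scatter. Between compound 2 and compound 3 the step of a number 6.6 percentage points higher from compound 2 to compound 3 (within the scatter) stays within the scatter.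

Compound 4 `CCOC(=O)c1cn(C(c2ccccc2)c2cc3cc(Br)ccc3nc2OC)nn1` differs from compound 1 in another way: ethoxycarbonyl in place of butyl on an aromatic carbon. The chain is not extended but replaced; the measured steps only lengthen or cap the butyl chain four bonds from the aromatic carbon, so none of them bears directly on this exchange. The three measured numbers all lie in a narrow low band, and the two steps that left the scatter did so only modestly. A step in this assay close to the scatter, in either direction, is therefore expected, a number 6.5 percentage points higher from compound 1 to compound 4 (within the scatter). Compound 4 is estimated at 3%, within a range from -12% to 18%.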

Compound 4, a percentage reported as inhibition, at one concentration (the size of the read-out at that concentration, not a potency): 2%
Compound 4: middle estimate off by 1 percentage points, on the high side, and the stated range covers the measured number.
By their numbers in this assay, from the lowest: compounds 1, 4, 2 and 3 (each within the scatter of the next, the first and the last beyond it).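

In this assay, going by these compounds alone, the earlier compounds varied only the length and the end of a chain, whereas here the chain gives way to ethoxycarbonyl on the same aromatic carbon, and the result is a number 5.5 percentage points higher from compound 1 to compound 4 (within the scatter) for this exchange. Butyl and ethoxycarbonyl therefore cannot be told apart on this read-out, although ethoxycarbonyl brings oxygen, a double bond and hydrogen-bond acceptors that butyl lacks, so the number stays level across that change of group, without a step beyond the scatter. Against the longer chains the comparison divides, with a number 12.6 percentage points lower from compound 3 to compound 4 (beyond the scatter) setting octyl apart from ethoxycarbonyl, while a number 6 percentage points lower from compound 2 to compound 4 (within the scatter) does not separate 5-hydroxypentyl from it, and no supporting evidence is available to explain either outcome.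

The compounds shown leave open whether a carboxylic acid, an amide or an amine on this aromatic carbon would stay in the same low band, and whether a chain longer than octyl would move the number further. They also leave open how any of these groups would read at concentrations other than the one tested.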